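Turning One Double Bond: Compound 1 to Compound 3

The source may hold more compounds than are shown below. What is called first, only, known or untested is meant among the compounds shown, and "the series" means these compounds.

Compound 1 `COc1ccc(/C=C\C(=O)O[C@@H](C)[C@@H]2CC[C@H]([C@H](O)[C@H]3CC=CC(=O)O3)O2)cc1` was tested in a functional assay on HeLa cells (Homo sapiens) for inhibition, read by sulforhodamine B assay, with a stated time of 72 h (on this read-out higher numbers stand for weaker inhibition and lower numbers for stronger inhibition), where compound 1 gives 4200 nM. Going by the values given here, of the two numbers measured so far, this is the highest, yet the only other compound sits within the usual scatter of it. That companion, compound 2 `C[C@H](OC(=O)/C=C\c1ccc(O)cc1)[C@@H]1CC[C@H]([C@H](O)[C@H]2CC=CC(=O)O2)O1`, gives 3300 nM in this assay. The measured step of a 1.3-fold lower number from compound 1 to compound 2 (0.10 log units; within the scatter) is a swap of a methyl on an aromatic oxygen for hydrogen.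

Compound 3 `COc1ccc(/C=C/C(=O)O[C@@H](C)[C@@H]2CC[C@H]([C@H](O)[C@H]3CC=CC(=O)O3)O2)cc1` has not yet been measured. Its difference from compound 1 is the two compounds have the same atoms and bonds and differ only in configuration as drawn: 1 of 6 stereo elements differ; a double bond is drawn Z in compound 1 and E in compound 3. Among the compounds with values here, the single measured step does not touch any double bond, so it offers no guidance on turning this bond from Z to E. With no comparable step in hand, the expected step of a 1.1-fold lower number from compound 1 to compound 3 (0.02 log units; within the scatter) is none beyond the scatter. Compound 3 is therefore estimated at 4000 nM, with an expected range from 1300 nM to 12000 nM. The width of that range reflects the absence of any measured step that bears on this change.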

Compound 3, half-maximal inhibitory concentration: 6000 nM
Compound 3: middle estimate off by 1.5-fold (0.18 log units), on the low side, and the stated range covers the measured number.
By their numbers in this assay, from the lowest: compounds 2, 1 and 3 (each within the scatter of the next).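

Going by these compounds alone, the earlier step changed only the group on the aromatic oxygen, so this is the first measured look at the double bond itself. In this assay, turning that bond from Z to E gives a 1.4-fold higher number from compound 1 to compound 3 (0.15 log units; within the scatter), so the two geometries cannot be told apart here, and at this position the bond's drawn configuration shows no effect beyond the scatter. The comparison is a clean one, with a single feature changed: the fact that compounds 1 and 3 differ only in the configuration as drawn.

Still open, going by these compounds, is whether a longer chain on the aromatic oxygen, or an amine in place of that oxygen, would shift the number beyond the scatter. Also open, on these data alone, is how the E double bond behaves with hydrogen rather than methyl on that oxygen, and whether the same holds in any other assay.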